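Furan to thiophene swap on an amide-bound methylene

The source may report more compounds than this note shows. Statements on the series, on what has been measured and on what is new or still open speak of the compounds shown alone.

Compound 1, `Nc1ccc(Nc2c(C(=O)NCc3ccc(F)cc3)nc(Br)c3cccnc23)cc1`, gives 7000 nM in a functional assay on MDA-MB-435 cells (Homo sapiens) for cytotoxicity, read by MTT assay, with a stated time of 72 h; on this read-out higher numbers stand for weaker inhibition and lower numbers for stronger inhibition.
Compound 2, `N[C@H]1CC[C@H](Nc2c(C(=O)NCc3ccco3)nc(Br)c3cccnc23)CC1`, gives only a limit of this assay, > 10000 nM.
Compound 3, `NCCNc1c(C(=O)NCc2ccc(F)cc2)nc(Br)c2cccnc12`, gives 12000 nM.

Compound 2 therefore does not stand at a number at all: its result is the limit at which the assay stops reporting, as shown by the limit of > 10000 nM in this assay, at which 1 of the 3 values shown sits. Compound 4, `N[C@H]1CC[C@H](Nc2c(C(=O)NCc3cccs3)nc(Br)c3cccnc23)CC1`, differs from compound 2 in one place: thiophen-2-yl in place of furan-2-yl on a saturated chain carbon bound to an amide-type nitrogen. Among the measured compounds shown here, the only step measured so far, a 1.7-fold higher number from compound 1 to compound 3 (0.23 log units; within the scatter), concerns a different position and a different kind of group, and it stays within the scatter, so no measured step bears directly on the furan to thiophene change. With compound 2 at the limit and no guidance pointing either way, the expectation for compound 4 is a result at or near that same limit, with no step beyond the scatter. For compound 4 the expected value is 15000 nM, between 6000 nM and 40000 nM. That estimate means a step that the limit leaves unreadable from compound 2 to compound 4.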

Compound 4, half-maximal inhibitory concentration: 4100 nM
Compound 4: middle estimate off by 3.7-fold (0.56 log units), on the high side; the measured number lies below the stated range.
By their numbers in this assay, from the lowest: compounds 4, 1 and 3 (each within the scatter of the next, the first and the last beyond it).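

In this assay, thiophen-2-yl in place of furan-2-yl gives an at least 2.4-fold lower number from compound 2 to compound 4 (0.38 log units; beyond the scatter), the first step shown that lies beyond the scatter. Among the compounds shown here, the earlier compounds showed only a change of the group on the other side of the shared core, and that step stayed within the scatter, so this is the first sign that the group on the saturated chain carbon bound to an amide-type nitrogen can alter the read-out. The true size of the step cannot be read, only its lower bound, because compound 2 stands at a limit of the assay: the limit of > 10000 nM in this assay, at which 1 of the 4 values shown sits.

As far as these compounds go, how a pyridine ring or a cyclopentyl group would fare at this same place remains open. So does whether the swap would give a similar step alongside 4-aminophenyl or 2-aminoethyl.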